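The compounds below may be only part of what the source reports. "The series", "measured", "known", "first", "only" and "open" are said of these compounds alone.

Series notes. Three ureas built on the shared core have been run through a functional assay on PC-3 cells (Homo sapiens) for inhibition, read by sulforhodamine B assay, with a stated time of 48 h, tested at 10 uM; on this read-out lower numbers stand for a stronger effect and higher numbers for a weaker effect at the one concentration tested. Compound 1 `COc1cc2cc(Oc3ccc(NC(=O)Nc4ccccc4)cc3)c(C)nc2cc1OC` carries an unsubstituted phenyl and gives 60.4%. Compound 2 `COc1cc2cc(Oc3ccc(NC(=O)Nc4ccc(C)cc4)cc3)c(C)nc2cc1OC` gives 94.5%. Compound 3 `COc1cc2cc(Oc3ccc(NC(=O)Nc4cccc(C(F)(F)F)c4)cc3)c(C)nc2cc1OC` gives 0.08%, the lowest of the three numbers: the nearest number is that of compound 1, and the furthest that of compound 2. The measured steps are a number 34.1 percentage points higher from compound 1 to compound 2 (beyond the scatter), a number 60.3 percentage points lower from compound 1 to compound 3 (beyond the scatter) and a number 94.4 percentage points lower from compound 2 to compound 3 (beyond the scatter), all large, and all concern the substituent on the terminal aryl ring.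

Compound 4 `COc1cc2cc(Oc3ccc(NC(=O)Nc4ccc(Cl)c(C(F)(F)F)c4)cc3)c(C)nc2cc1OC` adds to compound 3 the change (chloro in place of hydrogen on an aromatic carbon). Among the compounds with values here, no measured step involves a chloro group, so the three steps above bear on it only in showing that this ring position is sensitive. Compound 3 already sits near the floor of this assay, which leaves little room for a further drop. Compound 4 is therefore expected to show a number 2.9 percentage points higher from compound 3 to compound 4 (within the scatter), nothing beyond the scatter, and its value is estimated at 3%, within a range of 0% to 18%.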

Compound 4, a percentage reported as activity, at one concentration (the size of the read-out at that concentration, not a potency): -0.61%
The estimate for compound 4 lay 3.6 percentage points above the measured number, and the stated range ends above it.
By their numbers in this assay, from the lowest: compounds 4 and 3 (each within the scatter of the next); then compound 1; then compound 2.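

Working notes on the chloro change. In this assay, chloro on the aromatic carbon ortho to the trifluoromethyl group and para to a large group gives (a number 0.7 percentage points lower from compound 3 to compound 4 (within the scatter)), so this position accepts the added atom with no change in the read-out beyond the scatter. The large gaps to the other ureas persist, (a number 95.1 percentage points lower from compound 2 to compound 4 (beyond the scatter)) and (a number 61 percentage points lower from compound 1 to compound 4 (beyond the scatter)), but with both compound 3 and compound 4 close to the low end of the read-out, any further gain from chloro would hardly show at this single concentration, and no measurement on hand explains the outcome.

Open, as far as these compounds go, is whether chloro on the unsubstituted phenyl of compound 1, without the trifluoromethyl group, would move the number at all. Also open, from the compounds shown here alone, is whether an amine or a carboxylic acid on this same carbon would keep the number this low.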